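Adding a Methyl to the Hydroxy Group of Compound 1

The compounds below may be only part of what the source reports. "The series", "measured", "known", "first", "only" and "open" are said of these compounds alone.

Among the measured compounds shown here, in a functional assay on SF-539 cells (Homo sapiens) for cytotoxicity, read by sulforhodamine B assay, with a stated time of 48 h (a higher number here means a weaker inhibitor of growth, a lower number a stronger inhibitor of growth), compound 1 (`COc1cc(C(=O)c2ccc(OC)c(O)c2OC)cc(OC)c1O`) gives 611 nM and holds the lower of the two numbers so far. Compound 2 (`COc1cc(C(=O)c2ccc3c(c2)oc(=O)n3S(C)(=O)=O)cc(OC)c1OC`) gives 2360 nM by the same measure. That gap lies beyond the usual scatter, but the two structures differ in more than one place, so no single change can be read from it. Compound 3 (`COc1ccc(C(=O)c2cc(OC)c(OC)c(OC)c2)c(OC)c1O`) departs from compound 1 in one place only: methyl in place of hydrogen on an oxygen on an aromatic ring (methyl in place of hydrogen on an oxygen on an aromatic ring, hydroxy to methoxy). For the measured compounds named here, no measured pair shows this change, so what follows is a judgement and not a reading. In this assay stronger growth inhibition is expected, with an estimated 4.1-fold lower number from compound 1 to compound 3 (0.61 log units; beyond the scatter) toward a lower number and beyond the scatter. Compound 3 is estimated at 150 nM with an expected range from 35 nM to 650 nM as the likely span.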

Compound 3, concentration for 50% growth inhibition: 15.1 nM
Estimate against measurement, compound 3: 9.9-fold (1.00 log units) above; the measured number lies below the stated range.
By their numbers in this assay, from the lowest: compound 3; then compound 1; then compound 2.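

In this assay, among the compounds shown here, the change from hydroxy to methoxy, methyl in place of hydrogen on an oxygen on an aromatic ring, gives a 40-fold lower number from compound 1 to compound 3 (1.61 log units; beyond the scatter), the first step here that can be read at a single place. It shows that at this position the hydroxy hydrogen is not needed for growth inhibition, and that capping this oxygen with a methyl is a large gain on the core of compound 1. No evidence at hand bears on why this single methyl has so large an effect.

The compounds shown leave open whether a longer chain on this oxygen, such as ethyl, would keep the gain, or whether an amine could stand in place of the oxygen. For the compounds shown here, they also leave open what the hydroxy group that remains in compound 3 contributes, since no step shows a change at that place.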